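Methoxy Removal on Pyrazole Chalcones in K562 Growth Inhibition

A few compounds are considered here, and "the series" means these few. Any claim that something is new, unique, unknown or untested is made for them only; others in the source may bear on it.

Compound 1, `COc1cc(-c2cc(/C=C/C(=O)c3ccc(N)cc3)[nH]n2)cc(OC)c1OC`, gives 23600 nM in a functional assay on K562 cells (Homo sapiens) for inhibition, read by sulforhodamine B assay, with a stated time of 48 h; on this read-out higher numbers stand for weaker inhibition of growth and lower numbers for stronger inhibition of growth.
Compound 2, `COc1ccc(-c2cc(/C=C/C(=O)c3ccc(N)cc3)[nH]n2)cc1OC`, gives 36400 nM in this assay.
Compound 3, `COc1cc(C(=O)/C=C/c2cc(-c3cc(OC)c(OC)c(OC)c3)n[nH]2)cc(OC)c1OC`, reaches only a limit of the assay in this assay, namely > 100000 nM.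

Compound 1 and compound 2 share one core and differ in a single place: hydrogen in place of methoxy on an aromatic carbon. The resulting step, a 1.5-fold higher number from compound 1 to compound 2 (0.19 log units; within the scatter), is small, so the two values cannot be ordered against each other. Compound 3 is built on a different core; the difference between the core of compound 1 and the core of compound 3 is not broken down here. For compound 3 only a limit is known.

Compound 4, `COc1ccc(-c2cc(/C=C/C(=O)c3cc(OC)c(OC)c(OC)c3)[nH]n2)cc1OC`, has not yet been measured. For the measured compounds named here, it arises from compound 3 by hydrogen in place of methoxy on an aromatic carbon, which is the same change, in the same surroundings, as the one that leads from compound 1 to compound 2. The expectation for compound 4 rests on two things: the measured change gave a 1.5-fold higher number from compound 1 to compound 2 (0.19 log units; within the scatter), so little movement is expected, and compound 3 already sits at the limit of > 100000 nM in this assay, at which 1 of the 3 values shown sits, so compound 4 would most likely also be reported only as a limit. The step expected from this change is a step that the limit leaves unreadable from compound 3 to compound 4. Compound 4 is therefore estimated at 150000 nM, with the likely range spanning 60000 nM to 500000 nM.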

Compound 4, concentration for total growth inhibition: 9710 nM
Compound 4: the middle estimate sits 15-fold (1.19 log units) above what was measured, and the stated range ends above it.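

In this assay, replacing methoxy with hydrogen on an aromatic carbon gave an at least 10-fold lower number from compound 3 to compound 4 (1.01 log units; beyond the scatter), so on these two cores the same change did not produce a step of the same size. Set side by side, the two steps differ: the same change on two cores in this assay, a 1.5-fold higher number (0.19 log units; within the scatter) from compound 1 to compound 2 and an at least 10-fold lower number (1.01 log units; beyond the scatter) from compound 3 to compound 4, at least 15-fold (1.20 log units) apart, beyond the scatter of two such steps. The value of compound 3, > 100000 nM, is a limit of the assay and not a number, so the true size of the second step stays unknown, and two pairs give neither a reason for the difference nor a rule for any further core.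

The compounds shown leave open how the result would change if a hydroxyl, a fluorine atom or a longer chain such as ethoxy stood on the aromatic carbon that loses methoxy in going to compound 4. They also leave open whether the amine of compound 1 and the methoxy groups on the carbonyl side of compound 3 are what separates the two outcomes, since a core carrying an acetamide or a single methoxy group there would be needed to tell these apart.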